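Chain-carbon substitution and a ring change in the thiazole acetic acid series

The source may report more compounds than this note shows. Statements on the series, on what has been measured and on what is new or still open speak of the compounds shown alone.

Measured so far in an in vitro functional assay on HEK285-7 cells for antagonist activity at prostaglandin D2 receptor 2 (Homo sapiens), read by BRET and beta-arrestin recruitment; a lower number here means a smaller maximal response, a higher number a larger maximal response:
- compound 1, `O=C(O)Cc1sc(Cc2ccccc2)nc1-c1ccc(Cl)cc1`: 50%
- compound 2, `CCC(c1ccccc1)c1nc(-c2ccc(Cl)cc2)c(CC(=O)O)s1`: 50%
- compound 3, `O=C(O)Cc1sc(C(c2ccccc2)c2ccc(Cl)cc2)nc1-c1ccc(Cl)cc1`: 80%

Compound 3 gives the highest maximal response of the three. The steps of a number 30 percentage points higher from compound 1 to compound 3 (beyond the scatter) and a number 30 percentage points higher from compound 2 to compound 3 (beyond the scatter) both lie beyond the scatter, whereas no change at the digits printed from compound 1 to compound 2 (within the scatter) stays within it. In both steps that lie beyond the scatter a 4-chlorophenyl enters on the saturated chain carbon bound to two aromatic carbons.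

Compound 4, `COc1ccc(C(c2ccccc2)c2nc(-c3ccc(Cl)cc3)c(CC(=O)O)s2)cc1`, is not yet measured. It differs from compound 3 by methoxy in place of chloro on an aromatic carbon, the ring now carrying a methoxy where compound 3 carries chloro, para to a large group. Going by the values given here, none of the measured steps touches this ring: all three concern the saturated chain carbon. Among the compounds with values here, there is therefore no direct precedent for the size or direction of this change. Given that the aryl substituent on the chain carbon is retained, the expectation is that compound 4 remains close to compound 3, with a step of a number 5 percentage points lower from compound 3 to compound 4 (within the scatter) expected, within or at the edge of the scatter. Compound 4 is thus estimated at 75% in this assay, with a range from 55% to 95%.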

Compound 4, largest response reached (reported as efficacy), in percent of the reference or control that the assay uses: 80%
The estimate for compound 4 lay 5 percentage points below the measured number; low and high end bracket the measured number.
By their numbers in this assay, from the lowest: compounds 1 and 2 (each within the scatter of the next); then compounds 3 and 4 (each within the scatter of the next).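

In this assay, methoxy in place of chloro, para to a large group, gives no change at the digits printed from compound 3 to compound 4 (within the scatter), so this ring position accepts either group with no readable shift in maximal response. The rise seen with 4-chlorophenyl on the chain carbon is therefore not tied to chlorine: 4-methoxyphenyl in place of hydrogen gives a number 30 percentage points higher from compound 1 to compound 4 (beyond the scatter), and 4-methoxyphenyl in place of ethyl gives a number 30 percentage points higher from compound 2 to compound 4 (beyond the scatter), the same printed size as the corresponding steps to compound 3. Nothing available explains why the two para groups read alike.

Open, going by these compounds, is whether a plain phenyl on the chain carbon would already give this rise. Also open, on these data alone, is whether a hydroxyl or dimethylamino group at the same ring position would keep the response of compound 3 and compound 4.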